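This account rests on a few compounds, and the source may have more. Where it says the series, first, only, none or still open, it means among the compounds named here.

Three compounds have numbers in an assay for inhibition of 15-hydroxyprostaglandin dehydrogenase [NAD(+)] (Homo sapiens), read by fluorescence, with a stated time of 15 min, in the presence of a further agent that is not named here; a lower number here means a stronger inhibitor, a higher number a weaker inhibitor. Compound 1 `CCCC[S+]([O-])c1sc2nc(-c3nccs3)cc(-c3cccc(CO)c3)c2c1N` gives 4.3 nM, and compound 3 `CCCC[S+]([O-])c1sc2nc(-c3nc(C)cs3)cc(-c3cnc(C)n3C)c2c1N` gives 2.8 nM. Compound 2 `CCCC[S+]([O-])c1cc2c(-c3ccccc3)nc(-c3ccccc3)nc2s1` gives 93 nM, the highest of the three and beyond the scatter from both others, so compound 2 is the weakest inhibitor of this set. Among the measured compounds shown here, compound 2 also stands apart in lacking the amino group that compounds 1 and 3 both carry on the five-membered aromatic ring of the shared core; the three compounds differ in further places as well, so no single step among them isolates that group.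

Compound 4 `CCCC[S+]([O-])c1sc2nc(-c3ccccc3)nc(-c3ccccc3)c2c1N` is the amino analogue of compound 2: amino in place of hydrogen on an aromatic carbon. For the measured compounds named here, no pair of measured compounds shows this change on its own. The two amino-bearing compounds, compound 1 at 4.3 nM and compound 3 at 2.8 nM, both lie well below compound 2, but their other substituents differ too, so the share of the amino group in that gap cannot be read off. The added amino group is expected to bring a moderate step toward a lower number, a 3.7-fold lower number from compound 2 to compound 4 (0.57 log units; beyond the scatter). Compound 4 is estimated at 25 nM in this assay, with a range from 7 nM to 90 nM.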

Compound 4, half-maximal inhibitory concentration: 4.9 nM
Beside the measured number, compound 4's estimate is 5.1-fold (0.71 log units) above it, outside the stated range (below it).
By their numbers in this assay, from the lowest: compounds 3, 1 and 4 (each within the scatter of the next); then compound 2.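

In this assay, among the compounds shown here, amino in place of hydrogen on an aromatic carbon of the five-membered aromatic ring with one sulfur brings a 19-fold lower number from compound 2 to compound 4 (1.28 log units; beyond the scatter), a large step and the first one in which this group is the only thing that changes. The gap that earlier could be seen only between compounds differing in several places therefore has a direct reading here: this single change, with the butylsulfinyl chain and both phenyl groups left as they are, is enough to move the number well beyond the scatter. The data shown offer no measurement that bears on why the step has this size.

This is one pair, and compounds 1 and 3 have no partner shown without the amino group, so it remains open whether the step keeps its size alongside their other substituents. Going by these compounds, it also remains open whether a methylamino group, a hydroxyl group or a methyl group on the same aromatic carbon would give a comparable step, or whether the result belongs to the amino group alone.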